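Adding diethylamino to compound 2: working notes

The source may hold more compounds than are shown below. What is called first, only, known or untested is meant among the compounds shown, and "the series" means these compounds.

Of the compounds shown here, two have been read so far in a functional assay on MCF7 cells (Homo sapiens) for antiproliferative activity, read by MTT assay, with a stated time of 72 h; on this read-out higher numbers stand for weaker inhibition and lower numbers for stronger inhibition. Among the measured compounds shown here, compound 1 (`Oc1ccc2ccccc2c1/C=N/NC(=S)Nc1ccccc1`) gives 3300 nM in this assay, which is the only reading so far that is a number. Compound 2 (`NC(=S)N/N=C/c1ccccc1O`) gives >= 5000 nM, and this reading is a limit of the assay rather than a number. That leaves compound 2 with a limit and no exact position: the limit of >= 5000 nM in this assay, at which 1 of the 2 values shown sits.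

Compound 3 (`CCN(CC)c1ccc(/C=N/NC(N)=S)c(O)c1`) is compound 2 with a single change: diethylamino in place of hydrogen on an aromatic carbon. The diethylamino group sits on an aromatic carbon, meta to a hydroxy group and para to a group of 6 heavy atoms.

For the measured compounds named here, no measured step covers this change, so the expectation is tentative. A modest move toward stronger inhibition in this assay is expected, with no change beyond the scatter remaining possible. Going by the values given here, the working guide is compound 1 at 3300 nM, the only numerical reading available. The estimate implies an expected change of an at least 1.6-fold lower number from compound 2 to compound 3 (0.22 log units; that floor lies within the scatter). Compound 3 is estimated at 3000 nM, with an expected range of 800 nM to 10000 nM.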

Compound 3, half-maximal inhibitory concentration: 400 nM
The estimate for compound 3 lay 7.5-fold (0.88 log units) above the measured number; the whole stated range lies above it.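

On the aromatic carbon meta to a hydroxy group and para to a group of 6 heavy atoms, diethylamino in place of hydrogen gives, in this assay, an at least 12-fold lower number from compound 2 to compound 3 (1.09 log units; beyond the scatter), the only single-place step among the compounds shown and one that lies beyond the scatter. The earlier compounds shown here gave no reading of this position, and compound 3 now shows that this carbon can carry a group of 5 heavy atoms while inhibition in this read-out becomes clearly stronger. The step has a floor and no upper bound, since compound 2 holds a limit of the assay and not a number: the limit of >= 5000 nM in this assay, at which 1 of the 3 values shown sits.

One step cannot tell whether the gain is particular to diethylamino or would also come with another group on the same carbon, and dimethylamino, methoxy or a carboxylic acid there would separate those readings. The compounds shown also leave open whether diethylamino at the matching position would give a similar step on the core of compound 1.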